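Swapping a silicon chain for furan-2-yl on a shared core

A few compounds are considered here, and "the series" means these few. Any claim that something is new, unique, unknown or untested is made for them only; others in the source may bear on it.

In a functional assay on U-373MG ATCC cells for inhibition, with U373 MG (Homo sapiens) as the target, read by MTT assay, with a stated time of 7 days (a lower number here means a stronger inhibitor of growth, a higher number a weaker inhibitor of growth), compound 1 `C[Si](C)(C)Cn1nnc2c(C(N)=O)ncn2c1=O` gives 45600 nM and compound 2 `C[Si](C)(C)CCOCn1nnc2c(C(N)=O)ncn2c1=O` gives 25300 nM. Within the data shown here, the measured step between them is a 1.8-fold lower number from compound 1 to compound 2 (0.26 log units; within the scatter), so compound 2 stands level with its only numerical neighbour. Compound 3 `COc1ccc(Cn2nnc3c(C(N)=O)ncn3c2=O)cc1OC`, whose group also holds an aromatic ring, reaches only an assay limit, > 50000 nM. Compound 4 `NC(=O)c1ncn2c(=O)n(Cc3ccco3)nnc12` differs from compound 2 by a group of 5 heavy atoms (4 carbon, 1 oxygen; one five-membered aromatic ring with 1 hetero atom) in place of a group of 7 heavy atoms (5 carbon, 1 oxygen, 1 silicon; no ring), on a saturated chain carbon bound to an aromatic nitrogen, with furan-2-yl as the entering group. That single measured step is small, and the ring-bearing compound 3 gave no number, so only a slight move towards weaker inhibition of growth is expected. The estimated step is a 1.5-fold higher number from compound 2 to compound 4 (0.18 log units; within the scatter). Compound 4 is expected near 38000 nM, with an estimated range of 18000 nM to 50000 nM.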

Compound 4, concentration for 50% growth inhibition: > 50000 nM
Compound 4: only a limit was reported; the forecaster's own chance of this, stated with the estimate: 40%; at least 1.3-fold (0.11 log units) between middle value and limit.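

Both groups holding an aromatic ring, in compound 3 and compound 4, now end at an assay limit rather than a number, while the two silicon chains give numbers: the limit of > 50000 nM in this assay, at which 2 of the 4 values shown sit. For furan-2-yl at this saturated chain carbon bound to an aromatic nitrogen, the steps are only floors: an at least 1.9-fold higher number from compound 2 to compound 4 (0.29 log units; that floor lies within the scatter), and an at least 1.0-fold higher number from compound 1 to compound 4 (0.04 log units; that floor lies within the scatter). From the compounds shown here alone, the true size of either step therefore remains unknown.

The compounds shown leave open whether an amine, a carboxylic acid or a longer all-carbon chain at this place would give a number. They also do not show how far the true values of compound 3 and compound 4 lie beyond their limit.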